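Methyl Added to a Pendant Phenyl Ring

The source may report more compounds than this note shows. Statements on the series, on what has been measured and on what is new or still open speak of the compounds shown alone.

Measured compounds:
compound 1, `CCc1cc(=O)c2ccc(Sc3cccc(Cl)n3)cc2o1`, > 31400 nM
compound 2, `CCc1cc(=O)c2ccc(Sc3cccc(Cl)n3)c(C)c2o1`, 23900 nM
compound 3, `CCc1cc(=O)c2ccc(OCc3ccccc3)c(C)c2o1`, 24800 nM

In a functional assay on KBVIN cells (Homo sapiens) for antiproliferative activity, read by sulforhodamine B assay, with a stated time of 72 h (on this read-out higher numbers stand for weaker inhibition of growth and lower numbers for stronger inhibition of growth), compound 1 sits at the limit of > 31400 nM in this assay, at which 1 of the 3 values shown sits, which is a limit of the assay and not a number. Compound 2 gives 23900 nM in this assay. Compound 3 gives 24800 nM in this assay, and the two values for compound 2 and compound 3 lie within the scatter of each other.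

Compound 1 and compound 2 differ by methyl in place of hydrogen on an aromatic carbon. This change gave an at least 1.3-fold lower number from compound 1 to compound 2 (0.11 log units; that floor lies within the scatter). Compound 3 carries a different core from compound 1; the difference between the two cores is not broken down here.

Compound 4, `CCc1cc(=O)c2ccc(OCc3cccc(C)c3)c(C)c2o1`, has not yet been measured. It stands to compound 3 as compound 2 stands to compound 1, by methyl in place of hydrogen on an aromatic carbon. The surroundings of the place are not the same: in compound 2 the new methyl sits on a ring that is part of a fused or bridged system of two rings, ortho to a fused ring, ortho to a group of 8 heavy atoms and meta to a fused ring, whereas in compound 4 it sits on a six-membered aromatic ring of carbon only, meta to a large group. It is therefore the same kind of change, not the same change.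

For the measured compounds named here, because the only measured instance, an at least 1.3-fold lower number from compound 1 to compound 2 (0.11 log units; that floor lies within the scatter), has a floor that lies within the scatter, the step from compound 3 to compound 4 is expected to be small, a 1.2-fold lower number from compound 3 to compound 4 (0.09 log units; within the scatter). Compound 4 is accordingly estimated at 20000 nM, between 8000 nM and 50000 nM.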

Compound 4, concentration for 50% growth inhibition: 24900 nM
Compound 4: the middle estimate sits 1.2-fold (0.10 log units) below what was measured; measured number inside the range.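

In this assay, the change from phenyl to 3-methylphenyl gave a 1.0-fold higher number from compound 3 to compound 4 (0.00 log units; within the scatter), so on the core of compound 3 the added methyl left the number unchanged within the scatter. For compound 1 the value is > 31400 nM, which is a limit of the assay and not a number. The result therefore shows no measurable gain from this methyl on the core of compound 3, but it does not show that the change acts alike on both cores, as the earlier step is known only by its floor: the same change on two cores in this assay, an at least 1.3-fold lower number (0.11 log units; that floor lies within the scatter) from compound 1 to compound 2 and a 1.0-fold higher number (0.00 log units; within the scatter) from compound 3 to compound 4; the limit leaves it open whether they differ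

The compounds shown leave open whether a chlorine, a methoxy group or an amine at the same place on the phenyl ring would move the number in this assay beyond the scatter. They also leave open whether a carboxylic acid on that ring, or a longer chain on the shared core, would do so.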